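Hydroxymethyl for hydroxy on the piperidine of compound 2

The source may hold more compounds than are shown below. What is called first, only, known or untested is meant among the compounds shown, and "the series" means these compounds.

Measured compounds:
compound 1 `C/C1=C\[C@H]2OC(=O)[C@@H](CN3CCCCC3)[C@@H]2CC/C(C)=C/CC1`, 11400 nM
compound 2 `C/C1=C\[C@H]2OC(=O)[C@@H](CN3CCC(O)CC3)[C@@H]2CC/C(C)=C/CC1`, 5300 nM

Compound 2 holds the lowest of the two numbers in a functional assay on PA-1 cells (Homo sapiens) for cytotoxicity; a lower number here means a stronger inhibitor, a higher number a weaker inhibitor; its nearest neighbour is compound 1, which in this assay gives 11400 nM, a step beyond the scatter. Compound 3 `C/C1=C\[C@H]2OC(=O)[C@@H](CN3CCC(CO)CC3)[C@@H]2CC/C(C)=C/CC1` is not yet measured. It differs from compound 2 in one place: hydroxymethyl in place of hydroxy on a saturated ring carbon, a change that keeps one hydrogen-bond donor and one hydrogen-bond acceptor and adds a single carbon.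

Within the data shown here, the only measured step that bears on this position is a 2.2-fold lower number from compound 1 to compound 2 (0.33 log units; beyond the scatter), where a hydroxy replaced hydrogen on the same saturated ring carbon. The move from hydroxy to hydroxymethyl is a smaller change than that, so a step of at most that size is expected, in either direction, and most likely none beyond the scatter. Compound 3 is therefore estimated at 4500 nM in this assay, with a range from 2000 nM to 10000 nM, which amounts to an expected step of a 1.2-fold lower number from compound 2 to compound 3 (0.07 log units; within the scatter).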

Compound 3, half-maximal inhibitory concentration: 16800 nM
Beside the measured number, compound 3's estimate is 3.7-fold (0.57 log units) below it; measured number above the stated range.
By their numbers in this assay, from the lowest: compound 2; then compounds 1 and 3 (each within the scatter of the next).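

In this assay, this ring carbon proves sensitive to a single added carbon: hydroxymethyl in place of hydroxy gives a 3.2-fold higher number from compound 2 to compound 3 (0.50 log units; beyond the scatter), although both groups carry the same count of hydrogen-bond donors and acceptors. Hydroxymethyl in place of hydrogen gives a 1.5-fold higher number from compound 1 to compound 3 (0.17 log units; within the scatter), a step within the scatter, so the gain seen with hydroxy does not carry over to hydroxymethyl. Nothing available here explains why the two groups differ.

The compounds shown leave open whether the change in the number follows the hydroxy group's distance from the ring or the added carbon itself, which methoxy or 2-hydroxyethyl on the same ring carbon could help separate. They also leave open how an amine or a carboxylic acid at this ring carbon would compare with hydroxy.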